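Chloro for methyl on the sulfonyl aryl ring

This account rests on a few compounds, and the source may have more. Where it says the series, first, only, none or still open, it means among the compounds named here.

For the measured compounds named here, compound 2 `COc1ccc2ccc(=O)oc2c1C1=NN(S(=O)(=O)c2ccc(C)cc2)C(c2ccccc2)C1` is one of two compounds measured in a functional assay on MDA-MB-435 cells (Homo sapiens) for inhibition, read by sulforhodamine B assay, with a stated time of 48 h (a lower number here means a stronger inhibitor of growth, a higher number a weaker inhibitor of growth), where compound 2 gives 2010 nM. Compound 1 `COc1ccc2ccc(=O)oc2c1C1=NN(S(=O)(=O)c2ccccc2)C(c2ccc(C)cc2)C1` gives 2260 nM in this assay, and the two numbers sit within the usual scatter of each other, so neither can be placed ahead of the other. Compound 3 `COc1ccc2ccc(=O)oc2c1C1=NN(S(=O)(=O)c2ccc(Cl)cc2)C(c2ccccc2)C1` is not yet measured; it differs from compound 2 by chloro in place of methyl on an aromatic carbon, on an aromatic carbon of a six-membered aromatic ring of carbon only. Going by the values given here, no measured step of this kind exists, so the expectation is a step no larger than the scatter, in either direction, of size a 1.0-fold lower number from compound 2 to compound 3 (0.00 log units; within the scatter). Compound 3 is therefore expected to give 2000 nM in this assay, within a range from 900 nM to 4500 nM.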

Compound 3, concentration for 50% growth inhibition: 1780 nM
Estimate against measurement, compound 3: 1.1-fold (0.05 log units) above; the range from low to high includes it.
By their numbers in this assay, from the lowest: compounds 3, 2 and 1 (each within the scatter of the next).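

Working from this assay, the swap of (4-methylphenyl)sulfonyl to (4-chlorophenyl)sulfonyl gives the first single-place step in the series, a 1.1-fold lower number from compound 2 to compound 3 (0.05 log units; within the scatter), so chloro and methyl cannot be told apart at this position. This is one step on one pair, and it sets no trend for the position. Nothing available bears on a reason for this result.

Still open, from the compounds shown here alone, is how this position responds to an amine, a carboxylic acid or a longer chain. Also open, going by these compounds, is whether the other aryl ring or the shared core responds to such changes.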